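From methyl to methoxymethyl on the furan of compound 3

A few compounds are considered here, and "the series" means these few. Any claim that something is new, unique, unknown or untested is made for them only; others in the source may bear on it.

Measured in a functional assay on BXPC-3 cells (Homo sapiens) for cytotoxicity, read by MTT assay, with a stated time of 72 h; a lower number here means a stronger inhibitor, a higher number a weaker inhibitor:
- compound 1 `CC(C)c1[nH]cnc1/C=c1\[nH]c(=O)/c(=C/c2cccc(C(=O)c3ccc(F)cc3)c2)[nH]c1=O`: 0.6 nM
- compound 2 `O=C(c1ccc(F)cc1)c1cccc(/C=c2\[nH]c(=O)/c(=C/c3nc[nH]c3C3CC3)[nH]c2=O)c1`: 1.4 nM
- compound 3 `Cc1ccc(/C=c2\[nH]c(=O)/c(=C/c3cccc(C(=O)c4ccc(F)cc4)c3)[nH]c2=O)o1`: 3.7 nM

Of the three, compound 3 has the highest number, at 3.7 nM. The steps that lead to it are a 2.6-fold higher number from compound 2 to compound 3 (0.42 log units; beyond the scatter) and a 6.2-fold higher number from compound 1 to compound 3 (0.79 log units; beyond the scatter). Compound 4 `COCc1ccc(/C=c2\[nH]c(=O)/c(=C/c3cccc(C(=O)c4ccc(F)cc4)c3)[nH]c2=O)o1` differs from compound 3 only in its furan substituent, where 5-methylfuran-2-yl becomes 5-(methoxymethyl)furan-2-yl. This places methoxy in place of hydrogen on a saturated chain carbon bound to an aromatic carbon.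

For the measured compounds named here, no measured step alters this group, so the data give no direct reading of the change. The closest in kind is a 2.3-fold higher number from compound 1 to compound 2 (0.37 log units; beyond the scatter), which is also a small change to a carbon substituent on an aromatic ring and is modest in size. The two larger swaps above are modest too, and no step among these compounds is large. A modest step towards a higher number is therefore expected in this assay, though its direction rests on that single analogy. The expected step is a 1.9-fold higher number from compound 3 to compound 4 (0.28 log units; within the scatter). Compound 4 is estimated at 7 nM, with an expected range of 2.5 nM to 20 nM.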

Compound 4, half-maximal inhibitory concentration: 2 nM
Compound 4: middle estimate off by 3.5-fold (0.54 log units), on the high side; the measured number lies below the stated range.
By their numbers in this assay, from the lowest: compound 1; then compounds 2, 4 and 3 (each within the scatter of the next, the first and the last beyond it).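

In this assay, methoxy in place of hydrogen on a saturated chain carbon bound to an aromatic carbon is accommodated on the furan of compound 3, with a 1.9-fold lower number from compound 3 to compound 4 (0.27 log units; within the scatter), so this position takes the methyl to methoxymethyl change without a step beyond the scatter. The change also alters how the furan compares with the imidazoles: a 2.6-fold higher number from compound 2 to compound 3 (0.42 log units; beyond the scatter) lay beyond the scatter, whereas a 1.4-fold higher number from compound 2 to compound 4 (0.15 log units; within the scatter) lies within it, and the gap to the isopropyl imidazole remains beyond the scatter, with a 3.3-fold higher number from compound 1 to compound 4 (0.52 log units; beyond the scatter). Nothing available here explains this reading at the furan substituent.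

The compounds shown leave open whether an amine, a carboxylic acid or a longer ether chain on the same saturated chain carbon would stay within the scatter of compound 3 in this assay. They also leave open whether a methoxymethyl group in place of the isopropyl of compound 1 or the cyclopropyl of compound 2 would read as it does on the furan.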